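Fluorophenyl positional isomers on a shared amine nitrogen

This account rests on a few compounds, and the source may have more. Where it says the series, first, only, none or still open, it means among the compounds named here.

Measured compounds:
Compound 1 `COc1ccc(Nc2nc(-c3cccc(F)c3)nc3ccc(F)cc23)cc1`: 46800 nM
Compound 2 `Fc1cccc(Nc2nc(-c3cccc(F)c3)nc3ccc(F)cc23)c1`: > 50000 nM

In a functional assay on COLO 205 cells (Homo sapiens) for cytotoxicity, read by MTT assay, with a stated time of 48 h (on this read-out higher numbers stand for weaker inhibition and lower numbers for stronger inhibition), compound 1 gives 46800 nM. For compound 2 only a limit is known, > 50000 nM. For the measured compounds named here, the single measured step, an at least 1.0-fold higher number from compound 1 to compound 2 (0.02 log units; that floor lies within the scatter), sits at the limit of > 50000 nM in this assay, at which 1 of the 2 values shown sits, and shows nothing beyond the scatter. Compound 3 `Fc1cccc(-c2nc(Nc3ccccc3F)c3cc(F)ccc3n2)c1` is not yet measured; it differs from compound 2 by 2-fluorophenyl in place of 3-fluorophenyl on a nitrogen on an aromatic ring. Going by the values given here, no measured step moves a fluorine around this ring, so the expected step is a number no higher from compound 2 to compound 3 (the limit leaves the size open), none beyond the scatter. Compound 3 is therefore estimated at 50000 nM, within 20000 nM to 120000 nM, with a real chance that this assay again reports only a limit.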

Compound 3, half-maximal inhibitory concentration: > 50000 nM
Compound 3 was reported as a limit (the forecaster's own chance of this, stated with the estimate: 60%); the middle value lies on the limit itself.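

In this assay, 2-fluorophenyl on the nitrogen in place of 4-methoxyphenyl gives an at least 1.0-fold higher number from compound 1 to compound 3 (0.02 log units; that floor lies within the scatter), so this second fluorophenyl group also shows no step beyond the scatter. The step between the two fluorophenyl compounds cannot be read, as both values are limits. Both fluorine placements now stand at the same limit: the limit of > 50000 nM in this assay, at which 2 of the 3 values shown sit.

Any order between the 2-fluorophenyl and 3-fluorophenyl groups stays open. So does whether a phenyl carrying an amine or a carboxylic acid on this nitrogen would give a number clearly lower than that of compound 1.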